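Solubility Along a Ring Replacement

This account rests on a few compounds, and the source may have more. Where it says the series, first, only, none or still open, it means among the compounds named here.

Compound 1, `Cc1cc(-c2cnc(NCc3c(F)ccc4c3CCO4)c3cn[nH]c(=O)c23)n(C)n1`, was measured in a physicochemical assay for solubility, read by LC-MS, in phosphate buffer, with a stated time of 24 h, at pH 7.4 (on this read-out lower numbers stand for lower solubility and higher numbers for higher solubility), where compound 1 gives 1000 nM. Compound 2, `CC1(C)CC(=O)N(c2cnc(NCc3c(F)ccc4c3CCO4)n3cnnc23)C1`, was measured in the same way; in this assay compound 2 gives 57000 nM. Of the two numbers recorded so far, compound 1 stands as the lowest, and the gap from compound 1 to compound 2 lies beyond the usual scatter of repeated measurements of this kind.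

Compound 3, `CC(=O)N1CCC(c2cnc(NCc3c(F)ccc4c3CCO4)c3cn[nH]c(=O)c23)CC1`, has not yet been measured in this assay. It differs from compound 1 in one place: 1-acetylpiperidin-4-yl in place of 1,3-dimethyl-1H-pyrazol-5-yl on an aromatic carbon. Going by the values given here, no pair of measured compounds that differ in exactly one place is available, so the size of this step cannot be read from the data. For compound 3, a rise in this assay is expected, a 5.0-fold higher number from compound 1 to compound 3 (0.70 log units; beyond the scatter), a modest one in the same direction as compound 2. Compound 3 is therefore estimated at 5000 nM, with a range from 1500 nM to 20000 nM.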

Compound 3, solubility: < 2000 nM
Compound 3 was reported as a limit (the forecaster's own chance of this, stated with the estimate: 5%); middle value at least 2.5-fold (0.39 log units) from the limit.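

In this assay compound 3 gives < 2000 nM, which is a limit of the assay and not a number, and the step from compound 1 to compound 3 cannot be read. The compounds shown leave open whether 1-acetylpiperidin-4-yl in place of 1,3-dimethyl-1H-pyrazol-5-yl raises or lowers solubility, or leaves it within the usual scatter.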